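Swapping a Ring for a Chain in a Histamine Agonist

The source may report more compounds than this note shows. Statements on the series, on what has been measured and on what is new or still open speak of the compounds shown alone.

Compound 1 `Cc1nc(N)sc1CCCN/C(N)=N/C(=O)NCC(C)CCc1ccccc1` gives 29.5 nM in a functional assay on membranes from Sf9 cells for agonist activity at histamine H2 receptor (Homo sapiens), read by scintillation counting and GTPgammaS binding, with a stated time of 90 min; on this read-out lower numbers stand for an effect already at smaller amounts and higher numbers for an effect only at larger amounts of compound. Compound 2 `N/C(=N\C(=O)NCc1ccccc1)NC1CCc2nc(N)sc2C1` gives 214 nM in this assay, the higher of the two numbers, and its gap to compound 1 lies beyond the usual scatter of repeated measurements. Compound 3 `CCCCCCNC(=O)/N=C(\N)NC1CCc2nc(N)sc2C1` differs from compound 2 in one place: pentyl in place of phenyl on a saturated chain carbon bound to an amide-type nitrogen. Among the compounds with values here, no measured pair shows this exact change, so the step is expected to be modest and in no firm direction, likely within the scatter. Compound 3 is therefore expected to give about 200 nM, between 60 nM and 700 nM. The expected step is a 1.1-fold lower number from compound 2 to compound 3 (0.03 log units; within the scatter).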

Compound 3, half-maximal effective concentration: 148 nM
Compound 3: middle estimate off by 1.4-fold (0.13 log units), on the high side, within the range that was stated.
By their numbers in this assay, from the lowest: compound 1; then compounds 3 and 2 (each within the scatter of the next).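

In this assay, a pentyl in place of phenyl on a saturated chain carbon bound to an amide-type nitrogen leaves the number essentially unchanged (a 1.4-fold lower number from compound 2 to compound 3 (0.16 log units; within the scatter)). Until now, nothing showed how this position responds to losing its aromatic ring. In this one pair, an open carbon chain serves as well as the ring on the shared core, so the ring is not needed to keep this level of effect.

On these data alone, whether a longer chain, or a chain ending in an amine or a carboxylic acid, would do the same stays open. Nothing available here gives a reason for this result.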